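Furan-2-yl Ketone Variant in the HepG2 Cytotoxicity Series

The compounds below may be only part of what the source reports. "The series", "measured", "known", "first", "only" and "open" are said of these compounds alone.

The series shares a core carrying a trimethoxyphenyl-substituted triazole fused to a thiazine, a furan-2-yl at the saturated ring carbon, and an aryl ketone. Compound 1 `COc1cc(-c2nnc3n2NC(c2ccco2)C(C(=O)c2ccc(C)cc2)S3)cc(OC)c1OC` gives 17400 nM in a functional assay on HepG2 cells (Homo sapiens) for cytotoxicity, read by MTT assay, with a stated time of 48 h; on this read-out lower numbers stand for stronger inhibition and higher numbers for weaker inhibition. Compound 2 `COc1ccc(C(=O)C2Sc3nnc(-c4cc(OC)c(OC)c(OC)c4)n3NC2c2ccco2)cc1` returns only a limit of the assay, > 100000 nM, in this assay. Among the compounds with values here, the single measured step is an at least 5.7-fold higher number from compound 1 to compound 2 (0.75 log units; beyond the scatter), and its size is set by the limit of > 100000 nM in this assay, at which 1 of the 2 values shown sits, rather than by a finished number. Compound 3 `COc1cc(-c2nnc3n2NC(c2ccco2)C(C(=O)c2ccco2)S3)cc(OC)c1OC` replaces the ketone aryl group: furan-2-yl in place of 4-methoxyphenyl on a carbonyl carbon. Within the data shown here, no measured step covers the exchange of the whole aryl group on the carbonyl carbon, so the methyl-to-methoxy step bears on it only in that compound 2 sits at the limit and compound 1 sits at a finished number. The step from compound 2 to compound 3 is expected to read an at least 2.5-fold lower number from compound 2 to compound 3 (0.39 log units; beyond the scatter). Compound 3 is estimated at 40000 nM, within 10000 nM to 200000 nM.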

Compound 3, half-maximal inhibitory concentration: > 100000 nM
Compound 3: a limit, no number (the forecaster's own chance of this, stated with the estimate: 40%); middle value at least 2.5-fold (0.39 log units) from the limit.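

On the carbonyl carbon, furan-2-yl joins 4-methoxyphenyl at the limit: in this assay compound 3 gives > 100000 nM, a limit of the assay and not a number. Furan-2-yl in place of 4-methylphenyl reads as an at least 5.7-fold higher number from compound 1 to compound 3 (0.75 log units; beyond the scatter), so the rise from the finished value of compound 1 is no longer tied to the methoxy exchange alone. The step between compound 2 and compound 3 cannot be read, and the readable step gives only a lower bound on its size: the limit of > 100000 nM in this assay, at which 2 of the 3 values shown sit.

Going by these compounds, how far compound 2 and compound 3 lie past the limit remains open, as does whether any group other than 4-methylphenyl gives a finished number here. A longer alkyl chain in place of the methyl of compound 1, or an amine on that ring, would test this.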